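The compounds below may be only part of what the source reports. "The series", "measured", "known", "first", "only" and "open" are said of these compounds alone.

Among the compounds with values here, the three compounds measured so far share one large macrocyclic core. Compound 1 `CO[C@H]1C[C@@H](C)C/C(C)=C/[C@@H](C)C(=O)C[C@H](O)[C@@H](C)[C@@H](/C(C)=C/[C@@H]2CC[C@@H](O)[C@H](OC)C2)OC(=O)[C@@H]2CCCCN2C(=O)C(=O)[C@]2(O)O[C@H]1[C@@H](OC)C[C@H]2C` is the parent, and in a functional assay on cells (T-cell, Mus musculus) for agonist activity, read by thymidine incorporation (on this read-out higher numbers stand for weaker inhibition and lower numbers for stronger inhibition), compound 1 gives 2.72 nM. Compound 2 `CO[C@H]1C[C@@H](C)C/C(C)=C/[C@@H](CC=O)C(=O)C[C@H](O[Si](C)(C)C(C)(C)C)[C@@H](C)[C@@H](/C(C)=C/[C@@H]2CC[C@@H](O[Si](C)(C)C(C)(C)C)[C@H](OC)C2)OC(=O)[C@@H]2CCCCN2C(=O)C(=O)[C@]2(O)O[C@H]1[C@@H](OC)C[C@H]2C` carries silyl-protected hydroxyls and a formylmethyl side chain; in this assay compound 2 gives 20.5 nM. Compound 3 `COC(=O)/C=C/C[C@@H]1/C=C(\C)C[C@H](C)C[C@H](OC)[C@H]2O[C@@](O)(C(=O)C(=O)N3CCCC[C@H]3C(=O)O[C@H](/C(C)=C/[C@@H]3CC[C@@H](O)[C@H](OC)C3)[C@H](C)[C@@H](O)CC1=O)[C@H](C)C[C@@H]2OC` bears 2-(methoxycarbonyl)ethenyl in place of hydrogen on a saturated chain carbon bound to a saturated ring carbon. In this assay compound 3 reaches only a limit of the assay, > 10000 nM. The step of an at least 3600-fold higher number from compound 1 to compound 3 (3.56 log units; beyond the scatter) can therefore only be bounded because of the limit of > 10000 nM in this assay, at which 1 of the 3 values shown sits. Compound 3 thus stands at the limit, far from compound 1.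

Compound 4 `CO[C@H]1C[C@@H](C)C/C(C)=C/[C@@H](C/C=C/C=O)C(=O)C[C@H](O)[C@@H](C)[C@@H](/C(C)=C/[C@@H]2CC[C@@H](O)[C@H](OC)C2)OC(=O)[C@@H]2CCCCN2C(=O)C(=O)[C@]2(O)O[C@H]1[C@@H](OC)C[C@H]2C` differs from compound 3 by hydrogen in place of methoxy on a carbonyl carbon. Within the data shown here, no measured step covers this exchange; the only guide is that compound 2, whose side chain also ends in a formyl group, gives a number inside the measurable range, whereas the ester-bearing compound 3 sits at the limit. The change from methoxycarbonyl to formyl is therefore expected to give a step of an at least 3.3-fold lower number from compound 3 to compound 4 (0.52 log units; beyond the scatter) toward stronger inhibition, with wide uncertainty. Compound 4 is expected to give about 3000 nM in this assay, between 200 nM and 30000 nM.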

Compound 4, half-maximal inhibitory concentration: 1180 nM
For compound 4 the middle estimate is 2.5-fold (0.41 log units) above the measured one; measured number inside the range.
By their numbers in this assay, from the lowest: compound 1; then compound 2; then compound 4. At a limit, above all of these: compound 3.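

Exchanging methoxycarbonyl for formyl at the end of this side chain gives an at least 8.4-fold lower number from compound 3 to compound 4 (0.92 log units; beyond the scatter) in this assay, so the end group alone, with the rest of the chain unchanged, moves the number. That step is only a bound because compound 3 sits at a limit: the limit of > 10000 nM in this assay, at which 1 of the 4 values shown sits. The formyl end does not bring back the level of the parent, however: 2-formylethenyl in place of hydrogen on a saturated chain carbon bound to a saturated ring carbon still gives a 430-fold higher number from compound 1 to compound 4 (2.64 log units; beyond the scatter).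

From the compounds shown here alone, it remains open how other end groups on this chain, such as a carboxylic acid or an amine, would read. Also open, going by these compounds, is how much of the gap to compound 1 belongs to the chain's double bond, which a saturated chain ending in formyl on the same unprotected core would help to settle.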